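The source may report more compounds than this note shows. Statements on the series, on what has been measured and on what is new or still open speak of the compounds shown alone.

Values in a physicochemical assay for solubility, at pH 7.4 (on this read-out lower numbers stand for lower solubility and higher numbers for higher solubility), so far, by compound:
compound 1 `CC(=O)N1CCc2c(C)c3c(n2-c2ccc(C(N)=O)c(c2)N[C@@H](C)[C@H](C)C1)CC(C)(C)CC3=O` gives 38 ug/mL
compound 2 `Cc1c2c(n3c1CCN(C(=O)[C@@H](N)C(C)C)C[C@@H](C)[C@H](C)Nc1cc-3ccc1C(N)=O)CC(C)(C)CC2=O` gives > 100 ug/mL (a limit of the assay)

Compound 2 has only a limit, > 100 ug/mL, and no number.

Compound 3 `Cc1c2c(n3c1CCN(C(=O)C1(N)CCCC1)C[C@@H](C)[C@H](C)Nc1cc-3ccc1C(N)=O)CC(C)(C)CC2=O` is the next to be measured. The change is 1-aminocyclopentyl in place of 1-amino-2-methylpropyl on a carbonyl carbon, in words 1-aminocyclopentyl in place of 1-amino-2-methylpropyl on a carbonyl carbon.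

Among the measured compounds shown here, one measured step bears on this place, an at least 2.6-fold higher number from compound 1 to compound 2 (0.42 log units; beyond the scatter), which is beyond the scatter and replaced methyl with 1-amino-2-methylpropyl. For the measured compounds named here, no measured step compares the two amino-bearing groups now exchanged. The expectation rests on that single step, since both groups keep the amino group it introduced, so no further step beyond the scatter is expected in this assay. The expected step is a number no higher from compound 2 to compound 3 (the limit leaves the size open) and remains uncertain in size. For compound 3 the estimate is 100 ug/mL (expected range 50 ug/mL to 200 ug/mL).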

Compound 3, solubility: 53 ug/mL
Beside the measured number, compound 3's estimate is 1.9-fold (0.28 log units) above it; the range from low to high includes it.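

In this assay, 1-aminocyclopentyl in place of 1-amino-2-methylpropyl on a carbonyl carbon gives an at least 1.8-fold lower number from compound 2 to compound 3 (0.27 log units; that floor lies within the scatter). Against methyl at the same place, 1-aminocyclopentyl gives a 1.4-fold higher number from compound 1 to compound 3 (0.14 log units; within the scatter), whereas 1-amino-2-methylpropyl gave an at least 2.6-fold higher number from compound 1 to compound 2 (0.42 log units; beyond the scatter), so among these compounds an amino-bearing group at this place does not always bring a step beyond the scatter. The full size of the step to compound 3 stays unread because compound 2 carries only a limit: the limit of > 100 ug/mL in this assay, at which 1 of the 3 values shown sits.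

Still open, as far as these compounds go, is whether 1-aminocyclohexyl, or a chain ending in a carboxylic acid, at this place would differ from compound 3 by more than the scatter in this assay. Also open, from the compounds shown here alone, is how far compound 2 lies from compound 3, since the limit gives no number.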